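The compounds below may be only part of what the source reports. "The series", "measured", "known", "first", "only" and "open" are said of these compounds alone.

Measured so far:
- compound 1 `O=C(Nc1cc2ncncc2cc1OCc1ccc(F)cc1)Nc1cccc2ccccc12` gives 8300 nM
- compound 2 `O=C(Nc1cccc(Cl)c1)Nc1cc2ncncc2cc1OCc1cccc(Cl)c1` gives 3500 nM

In a functional assay on GBM3 cells (Homo sapiens) for antiproliferative activity, read by WST assay, with a stated time of 72 h (on this read-out lower numbers stand for stronger inhibition and higher numbers for weaker inhibition), compound 1, at 8300 nM, holds the higher of the two numbers, and compound 2 lies lower by more than the scatter. Within the data shown here, no measured pair differs in one place only, so the size of a single change remains unknown.

Compound 3 `O=C(Nc1cc2ncncc2cc1OCc1ccccc1Cl)Nc1cccc2ccccc12` differs from compound 1 as follows: 2-chlorophenyl in place of 4-fluorophenyl on a saturated chain carbon bound to an oxygen on an aromatic ring. This puts 2-chlorophenyl in place of 4-fluorophenyl on a saturated chain carbon bound to an oxygen on an aromatic ring. No step beyond the scatter is expected in this assay, with only a slight lean towards a lower number, as compound 2 at 3500 nM is the sole reference. The expected change is a 1.5-fold lower number from compound 1 to compound 3 (0.18 log units; within the scatter). For compound 3 the estimated value is 5500 nM, with an expected range from 2200 nM to 13000 nM.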

Compound 3, half-maximal inhibitory concentration: 2700 nM
The estimate for compound 3 lay 2.0-fold (0.31 log units) above the measured number; the range from low to high includes it.
By their numbers in this assay, from the lowest: compounds 3 and 2 (each within the scatter of the next); then compound 1.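

In this assay, the series now has its first comparison that differs in one place: 2-chlorophenyl in place of 4-fluorophenyl on a saturated chain carbon bound to an oxygen on an aromatic ring gives a 3.1-fold lower number from compound 1 to compound 3 (0.49 log units; beyond the scatter), so this position does respond to a change of substituted phenyl group. The two groups have the same count of heavy atoms and neither carries a hydrogen-bond donor or acceptor, so those counts do not separate them, and the change replaces fluorine with chlorine and moves the halogen at once. No measurement shown gives a reason for the step.

The compounds shown leave open whether the halogen or its place on the ring accounts for the step, which 4-chlorophenyl and 2-fluorophenyl would separate. Also open, from the compounds shown here alone, is how an unsubstituted phenyl or a longer chain would read at this position.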